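Swapping hydroxymethyl for methoxy on a furan-bearing core

The source may hold more compounds than are shown below. What is called first, only, known or untested is meant among the compounds shown, and "the series" means these compounds.

Measured compounds:
Compound 1 `COc1ccc(-c2nc(N)c3nc(-c4ccccc4)sc3n2)cc1`: 46.7 nM
Compound 2 `Nc1nc(-c2ccccc2)nc2sc(-c3ccco3)nc12`: 15 nM
Compound 3 `Nc1nc(-c2ccc(CO)cc2)nc2sc(-c3ccco3)nc12`: 3.58 nM

All three compounds were tested in an assay on CHO cells for displacement of a labelled ligand from adenosine receptor A3 (Homo sapiens), read by scintillation counting, with a stated time of 3 h; on this read-out higher numbers stand for weaker inhibition and lower numbers for stronger inhibition. Compound 3 gives the lowest number of the three; compound 2 sits nearest, a step away described by a 4.2-fold lower number from compound 2 to compound 3 (0.62 log units; beyond the scatter), and compound 1 sits furthest, with a gap beyond the scatter. Compound 1 and compound 2 differ in two places at once, so their values only show that compound 1 comes out weaker than compound 2, without telling which change is responsible.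

The next compound, compound 4 `COc1ccc(-c2nc(N)c3nc(-c4ccco4)sc3n2)cc1`, has not yet been measured in this assay. It differs from compound 3 in one place: methoxy in place of hydroxymethyl on an aromatic carbon. Among the measured compounds shown here, the only measured step that touches this position is a 4.2-fold lower number from compound 2 to compound 3 (0.62 log units; beyond the scatter), which shows that adding hydroxymethyl at this carbon strengthens binding modestly. Nothing measured shows whether methoxy at the same carbon keeps that gain, so the expectation leans toward a position between compound 2 and compound 3. Compound 4 is therefore expected to give roughly 10 nM in this assay, plausibly between 3 nM and 35 nM, corresponding to an expected step of a 2.8-fold higher number from compound 3 to compound 4 (0.45 log units; beyond the scatter).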

Compound 4, inhibition constant: 4.66 nM
Beside the measured number, compound 4's estimate is 2.1-fold (0.33 log units) above it; the range from low to high includes it.
By their numbers in this assay, from the lowest: compounds 3 and 4 (each within the scatter of the next); then compound 2; then compound 1.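

In this assay, the step of a 1.3-fold higher number from compound 3 to compound 4 (0.11 log units; within the scatter) means that hydroxymethyl and methoxy cannot be told apart at this carbon, although methoxy has 0 hydrogen-bond donors and hydroxymethyl has 1. The gain over hydrogen at the same carbon therefore survives the swap: a 3.2-fold lower number from compound 2 to compound 4 (0.51 log units; beyond the scatter) stands close in size to a 4.2-fold lower number from compound 2 to compound 3 (0.62 log units; beyond the scatter), so on these compounds that gain does not depend on a hydrogen-bond donor in the entering group. Compound 4 also separates the two changes that were mixed together between compound 1 and compound 2, since a 10-fold lower number from compound 1 to compound 4 (1.00 log units; beyond the scatter) isolates furan-2-yl in place of phenyl on the shared core, with methoxy held constant, and shows that this other position matters as well.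

From the compounds shown here alone, whether an amine, a carboxylic acid or a longer chain such as ethoxy at this carbon would hold the same level in this assay remains open, since two groups of similar size say little about how much room for change the position allows. No supporting data explain why hydroxymethyl and methoxy give matching results here.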